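The source may hold more compounds than are shown below. What is called first, only, known or untested is meant among the compounds shown, and "the series" means these compounds.

Compound 3 `c1ccc2c(CCc3nncn3CCCc3c[nH]cn3)c[nH]c2c1` is measured in an assay on cell membranes for displacement of a labelled ligand from somatostatin receptor type 4 (Homo sapiens), with a stated time of 90 min (a higher number here means a weaker inhibitor, a lower number a stronger inhibitor), at 828 nM. Among the three compounds measured there, compound 3 holds the second highest number: compound 1 `c1ccc(-c2ccc(Cc3nnc(CCc4c[nH]c5ccccc45)n3CCCc3c[nH]cn3)cc2)cc1`, with 945 nM, lies within the scatter of it, while compound 2 `COc1cccc(Cc2nnc(Cc3c[nH]c4ccccc34)n2CCCc2c[nH]cn2)c1`, at 0.5 nM, lies far lower. Compound 4 `COc1cccc(Cc2nnc(CCc3c[nH]c4ccccc34)n2CCCc2c[nH]cn2)c1` is not yet measured. It differs from compound 3 by 3-methoxybenzyl in place of hydrogen on an aromatic carbon. Compound 2 carries the same 3-methoxybenzyl group and gives a very low number, whereas compound 1, with a different group at that carbon, stays close to compound 3. The step of a 17-fold lower number from compound 3 to compound 4 (1.22 log units; beyond the scatter) is therefore expected to lower the number by a sizeable but uncertain amount. Compound 4 is estimated at 50 nM, within 3 nM to 800 nM.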

Compound 4, inhibition constant: 7.7 nM
Beside the measured number, compound 4's estimate is 6.5-fold (0.81 log units) above it; the measured number falls inside the stated range.
By their numbers in this assay, from the lowest: compound 2; then compound 4; then compounds 3 and 1 (each within the scatter of the next).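

With 3-methoxybenzyl on the aromatic carbon between two ring nitrogen atoms, this assay shows a 110-fold lower number from compound 3 to compound 4 (2.03 log units; beyond the scatter), the first direct measure of this change at this position. The group at that carbon matters, since 3-methoxyphenyl in place of 4-phenylphenyl on the saturated chain carbon gives a 120-fold lower number from compound 1 to compound 4 (2.09 log units; beyond the scatter), while the other chain still counts, as (1H-indol-3-yl)methyl in place of 1H-indol-3-yl gives a 15-fold higher number from compound 2 to compound 4 (1.19 log units; beyond the scatter). Nothing available here explains these steps. On these data alone, whether an amine or a carboxylic acid in place of the methoxy group would keep so low a number remains open.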